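Fused-ring methoxy analogue in the cytotoxicity series

This account rests on a few compounds, and the source may have more. Where it says the series, first, only, none or still open, it means among the compounds named here.

Measured so far:
compound 1, `Cc1ccc(-c2ccc(C)n2-c2ccc(-c3nc4ccc(F)cc4s3)cc2)cc1`: 33600 nM
compound 2, `Cc1ccc(-c2ccc(F)cc2)n1-c1ccc(-c2nc3ccc(F)cc3s2)cc1`: 37800 nM
compound 3, `COc1ccc(-c2ccc(C)n2-c2ccc(-c3nc4ccc(F)cc4s3)cc2)cc1`: 37800 nM

All three were run in an ADME assay on MCF-10A cells (Homo sapiens) for cytotoxicity, read by MTT assay, with a stated time of 72 h (a higher number here means a weaker inhibitor, a lower number a stronger inhibitor), and the numbers sit close together: a 1.1-fold higher number from compound 1 to compound 2 (0.05 log units; within the scatter), a 1.1-fold higher number from compound 1 to compound 3 (0.05 log units; within the scatter) and no change at the digits printed from compound 2 to compound 3 (within the scatter). None of the three can be set apart from the others.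

Compound 4, `COc1ccc2nc(-c3ccc(-n4c(C)ccc4-c4ccc(C)cc4)cc3)sc2c1`, has not yet been measured. It differs from compound 1 by methoxy in place of fluoro on an aromatic carbon. The same kind of change is made between two measured compounds: methoxy in place of fluoro on an aromatic carbon, which gave no change at the digits printed from compound 2 to compound 3 (within the scatter). The two places are not the same: in compound 3 the group sits on a six-membered aromatic ring of carbon only, para to a large group; in compound 4 it sits on a ring that is part of a fused or bridged system of two rings, meta to a fused ring and para to a fused ring. The cores of the two pairs also differ, by methyl in place of fluoro on an aromatic carbon.

Given that compound 2 and compound 3 show no change at the digits printed from compound 2 to compound 3 (within the scatter), compound 4 is expected to stay near compound 1, with a step of a 1.0-fold higher number from compound 1 to compound 4 (0.02 log units; within the scatter) in this assay. The estimate for compound 4 is 35000 nM, between 20000 nM and 60000 nM.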

Compound 4, half-maximal inhibitory concentration: 34000 nM
Compound 4: the middle estimate sits 1.0-fold (0.01 log units) above what was measured, and the stated range covers the measured number.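

In this assay, methoxy in place of fluoro on an aromatic carbon of a ring that is part of a fused or bridged system of two rings gives a 1.0-fold higher number from compound 1 to compound 4 (0.01 log units; within the scatter). Set beside the same change made on the other core, the two steps agree: the same change on two cores in this assay, no change at the digits printed (within the scatter) from compound 2 to compound 3 and a 1.0-fold higher number (0.01 log units; within the scatter) from compound 1 to compound 4, 1.0-fold (0.01 log units) apart, within the scatter of two such steps. This shows that the change carries from one core to the other in this series only in the sense that both steps stay within the scatter; it does not show that a step of real size would carry over, nor does it say how the change would behave on other cores or in any other assay.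

Going by these compounds, only methyl, fluoro and methoxy appear at the varied places, so it stays open whether any group there can move the number beyond the scatter. An amine, a carboxylic acid or a longer chain at either place would test this.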